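A few compounds are considered here, and "the series" means these few. Any claim that something is new, unique, unknown or untested is made for them only; others in the source may bear on it.

Compound 1 `CO[C@H]1C[C@H](Oc2cc(F)c(F)c(-c3cc(F)c(OCCCC(=O)O)c(F)c3)c2)C1` is known in a functional assay on CHO cells for agonist activity at Free fatty acid receptor 1 (Homo sapiens), read by calcium flux (on this read-out higher numbers stand for an effect only at larger amounts of compound and lower numbers for an effect already at smaller amounts), only as a limit: in this assay compound 1 gives > 100000 nM, a limit of the assay and not a number, as noted in the limit of > 100000 nM in this assay, at which 1 of the 2 values shown sits. Among the measured compounds shown here, its close relative compound 2 `CO[C@H]1C[C@H](Oc2cc(F)c(F)c(-c3cc(F)c(OCCCCC(=O)O)c(F)c3)c2)C1` carries carboxymethyl in place of carboxy on the chain; in this assay compound 2 gives 68800 nM, and the step of an at least 1.4-fold lower number from compound 1 to compound 2 (0.16 log units; that floor lies within the scatter) is the only measured step in this set. Compound 3 `COc1cc(F)c(F)c(-c2cc(F)c(OCCCC(=O)O)c(F)c2)c1` differs from compound 1 elsewhere: methyl in place of 3-methoxycyclobutyl on an oxygen on an aromatic ring. For the measured compounds named here, no measured step touches this ether, so the step from compound 1 to compound 2 gives no direct guidance on it, and the expectation rests on compound 1 standing at the limit. The estimate is that compound 3 stays weak, with an expected step that the limit leaves unreadable from compound 1 to compound 3. Compound 3 is therefore expected to give about 150000 nM, within 30000 nM to 800000 nM, most likely again reported only as a limit.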

Compound 3, half-maximal effective concentration: 24400 nM
Beside the measured number, compound 3's estimate is 6.1-fold (0.79 log units) above it; measured number outside the range, below it.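

The ether on the aromatic ring, which the earlier step along the chain did not touch, proves to be a position that matters in this assay: methyl in place of 3-methoxycyclobutyl on that oxygen gives an at least 4.0-fold lower number from compound 1 to compound 3 (0.61 log units; beyond the scatter). Among the compounds shown here, this is the first step in the set to lie beyond the scatter, and it comes with the loss of the four-membered ring and both defined stereocentres. Its size is only a floor, since compound 1 stands at a limit of the assay and not at a number: the limit of > 100000 nM in this assay, at which 1 of the 3 values shown sits.

From the compounds shown here alone, how an ethyl or an unsubstituted cyclobutyl on that oxygen would read remains open, so the step cannot yet be assigned to the ring, to the outer methoxy or to the overall size of the group. Also open, going by these compounds, is whether carboxymethyl in place of carboxy on the chain would change the number when the ether is methyl.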